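Chloro in place of fluoro on the aryl ring of compound 1

This account rests on a few compounds, and the source may have more. Where it says the series, first, only, none or still open, it means among the compounds named here.

Compound 1 `Cc1nc(C#Cc2cccc(F)c2)cs1` gives 23 nM in a functional assay on CHO cells for agonist activity at metabotropic glutamate receptor 5 (Homo sapiens), read by inositol phosphate accumulation (a higher number here means a weaker inhibitor, a lower number a stronger inhibitor), and so holds the lowest of the three numbers measured; compound 3 `COc1ccccc1C#Cc1csc(C)n1` gives 36.3 nM in this assay, within the scatter of compound 1, whereas compound 2 `Cc1nc(C#Cc2ccccc2F)cs1` gives 140 nM, beyond it. Among the measured compounds shown here, the single one-point step measured so far is a 3.9-fold lower number from compound 2 to compound 3 (0.59 log units; beyond the scatter). Compound 4 `Cc1nc(C#Cc2cccc(Cl)c2)cs1` differs from compound 1 by chloro in place of fluoro on an aromatic carbon. For the measured compounds named here, no measured pair exchanges these two halogens, and the step from compound 2 to compound 3 concerns another group on another carbon, so it bears only loosely here. The expected step is therefore a 1.2-fold lower number from compound 1 to compound 4 (0.06 log units; within the scatter), not beyond the scatter. Compound 4 is estimated at 20 nM in this assay, with a range of 7 nM to 60 nM.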

Compound 4, half-maximal inhibitory concentration: 129 nM
Compound 4: the middle estimate sits 6.5-fold (0.81 log units) below what was measured, and the stated range ends below it.
By their numbers in this assay, from the lowest: compounds 1 and 3 (each within the scatter of the next); then compounds 4 and 2 (each within the scatter of the next).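

Among the compounds shown here, the step of a 5.6-fold higher number from compound 1 to compound 4 (0.75 log units; beyond the scatter) is the first one measured at this aromatic carbon, and it shows that the position does not treat these two halogens alike in this assay. The change exchanges one heavy atom for one heavy atom, with no hydrogen-bond donor or acceptor entering or leaving, yet the step lies beyond the scatter. No measurement on hand accounts for the difference.

From the compounds shown here alone, whether any group at this carbon gives a lower number than fluoro remains open. A nitrile or an amine here, or plain hydrogen, would show how much the position tolerates.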